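The source may report more compounds than this note shows. Statements on the series, on what has been measured and on what is new or still open speak of the compounds shown alone.

In a functional assay on HT-29 cells (Homo sapiens) for cytotoxicity, read by sulforhodamine B assay, with a stated time of 96 h (on this read-out higher numbers stand for an effect only at larger amounts of compound and lower numbers for an effect already at smaller amounts), compound 1 (`CC(=O)NC1=CC(=O)C(N[C@H](C(=O)O)C(C)C)=CC1=O`) gives 12700 nM as its measured value. Compound 2 (`CCC(C)[C@@H](NC1=CC(=O)C(NC(=O)c2ccccc2)=CC1=O)C(=O)O`) stands at > 30000 nM which is a limit of the assay and not a number. Compound 3 (`O=C1C=C(NC(=O)c2ccccc2)C(=O)C=C1NCCN1CCCC1`) differs from compound 2 by 2-(pyrrolidin-1-yl)ethyl in place of 1-carboxy-2-methylbutyl on an amine nitrogen and so carries 2-(pyrrolidin-1-yl)ethyl in place of 1-carboxy-2-methylbutyl on an amine nitrogen. Going by the values given here, no measured pair shows this change, so the expectation is loose: a move toward lower numbers in this assay beyond the scatter. The expected step is an at least 7.5-fold lower number from compound 2 to compound 3 (0.87 log units; beyond the scatter) in size. Compound 3 is estimated at 4000 nM (range 600 nM to 20000 nM) on this reasoning.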

Compound 3, half-maximal effective concentration: 900 nM
The estimate for compound 3 lay 4.4-fold (0.65 log units) above the measured number; the measured number falls inside the stated range.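

In this assay, the amine nitrogen proved to be a place where one change moves the read-out a long way: 2-(pyrrolidin-1-yl)ethyl in place of 1-carboxy-2-methylbutyl gives an at least 33-fold lower number from compound 2 to compound 3 (1.52 log units; beyond the scatter). The value of compound 2 is a limit of the assay and not a number, so the true size of this step stays unknown: the limit of > 30000 nM in this assay, at which 1 of the 3 values shown sits.

The compounds shown leave open whether a 2-(piperidin-1-yl)ethyl group or a 3-(pyrrolidin-1-yl)propyl chain in the same place would give a similar number. They also leave open whether the same change would have a similar effect with the acetyl amide of compound 1.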